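The compounds below may be only part of what the source reports. "The series", "measured", "known", "first", "only" and "open" are said of these compounds alone.

Compound 1, `CCCCCCc1cc2c(=O)n(CCCSc3nc(-c4cc(OC)c(OC)c(OC)c4)c(C#N)c(=O)[nH]3)cnc2s1`: 28.1 ug/mL
Compound 2, `COc1cc(-c2[nH]c(=S)[nH]c(=O)c2C#N)cc(OC)c1OC`: > 100 ug/mL

Among the compounds with values here, in an ADME assay on PANC-1 cells (Homo sapiens) for inhibition, read by MTT assay (a higher number here means a weaker inhibitor of growth, a lower number a stronger inhibitor of growth), compound 1 gives 28.1 ug/mL, the only finite number in the set. Compound 2 returns only a limit of > 100 ug/mL in this assay, so its value is not a number (the limit of > 100 ug/mL in this assay, at which 1 of the 2 values shown sits). Within the data shown here, compound 1 therefore stands as the one compound with a measured growth inhibition here.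

Compound 3, `CCCc1cc2c(=O)n(CCCSc3nc(-c4cc(OC)c(OC)c(OC)c4)c(C#N)c(=O)[nH]3)cnc2s1`, differs from compound 1 in one place: hydrogen in place of propyl on a saturated chain carbon, three bonds along the chain from an aromatic carbon. Among the measured compounds shown here, no pair of measured compounds differs in a single place, so no measured step tells how large such a shortening of the chain should be. The change is expected to move this assay by a small amount, a weakening that may or may not exceed the usual scatter, as a 1.6-fold higher number from compound 1 to compound 3 (0.20 log units; within the scatter) states. Compound 3 is thus estimated at 45 ug/mL, with a range from 15 ug/mL to 100 ug/mL.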

Compound 3, concentration for 50% growth inhibition: > 100 ug/mL
Compound 3: a limit, no number; the forecaster's own chance of this, stated with the estimate: 25%; middle value at least 2.2-fold (0.34 log units) from the limit.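

Cutting the hexyl chain back to propyl is the first single change that can be read in this set, and in this assay it gives an at least 3.5-fold higher number from compound 1 to compound 3 (0.55 log units; beyond the scatter). This step lies beyond the scatter, so the length of the chain at this position is not indifferent: with the rest of the molecule unchanged, it separates a finite reading from a limit. The true size of the step stays unknown because compound 3 gives a limit and not a number: the limit of > 100 ug/mL in this assay, at which 2 of the 3 values shown sit.

The compounds shown leave open how the reading changes for butyl or pentyl, which lie between the two chains compared here. They also leave open whether a longer chain such as octyl, or an amine or a carboxylic acid at the end of the hexyl chain, would lower the number further or raise it.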